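Amide-side amine swap across two diaryl cores

This account rests on a few compounds, and the source may have more. Where it says the series, first, only, none or still open, it means among the compounds named here.

Measured in a functional assay on A2780 cells (Homo sapiens) for antiproliferative activity, read by MTT assay, with a stated time of 48 h; on this read-out higher numbers stand for weaker inhibition and lower numbers for stronger inhibition:
compound 1 `CCNCC(=O)Nc1cc(OC)ccc1C(=O)c1ccc(OC)c2c1C=CC(C)(C)O2`: 4090 nM
compound 2 `COc1ccc(C(=O)c2ccc(OC)c3c2C=CC(C)(C)O3)c(NC(=O)CN(C)C)c1`: 3990 nM
compound 3 `C=C(c1cc(OC)c(OC)c(OC)c1)c1ccc(OC)cc1NC(=O)CNCC`: 450 nM

Compound 3 sits lowest of the three; the difference between its core and the core of compound 1 is not broken down here. Within the first core the change dimethylamino in place of ethylamino on a saturated chain carbon bound to a carbonyl carbon gave a 1.0-fold lower number from compound 1 to compound 2 (0.01 log units; within the scatter). Compound 4 `C=C(c1cc(OC)c(OC)c(OC)c1)c1ccc(OC)cc1NC(=O)CN(C)C` carries the same change on the core of compound 3: dimethylamino in place of ethylamino on a saturated chain carbon bound to a carbonyl carbon, with the place the same in both pairs.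

For the measured compounds named here, for compound 4 in this assay the expected step is no change at the digits printed from compound 3 to compound 4 (within the scatter), resting on the single earlier instance, where the step from compound 1 to compound 2 stayed within the scatter. Compound 4 is therefore estimated at 450 nM, with a range from 200 nM to 1000 nM. Going by the values given here, only one prior instance supports this, so the range is kept wide.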

Compound 4, half-maximal inhibitory concentration: 240 nM
Beside the measured number, compound 4's estimate is 1.9-fold (0.27 log units) above it, within the range that was stated.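

In this assay the swap of ethylamino for dimethylamino gave a 1.9-fold lower number from compound 3 to compound 4 (0.27 log units; within the scatter). Set beside the earlier pair, the change carries from one core to the other with no step that stands out from the scatter: the same change on two cores in this assay, a 1.0-fold lower number (0.01 log units; within the scatter) from compound 1 to compound 2 and a 1.9-fold lower number (0.27 log units; within the scatter) from compound 3 to compound 4, 1.8-fold (0.26 log units) apart, within the scatter of two such steps. For the compounds shown here, this rests on only two pairs and a single place, so it shows neither a gain nor a loss from the change on either core, and it does not show that the same would hold on any further core.

The compounds shown leave open whether a primary amine or diethylamino on the same saturated chain carbon would also leave the number unmoved on both cores. Also open, from the compounds shown here alone, is whether a longer chain carrying the dimethylamino group would do the same.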